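Moving a Methyl Group Around the Ring

The source may report more compounds than this note shows. Statements on the series, on what has been measured and on what is new or still open speak of the compounds shown alone.

Of the compounds shown here, three sharing one core have been tested in a functional assay on SGC-7901 cells (Homo sapiens) for inhibition, read by MTT assay, with a stated time of 24 h; on this read-out higher numbers stand for weaker inhibition and lower numbers for stronger inhibition. Compound 1 `CC1(C)[C@H]2CC[C@]1(C)N(Cc1cn(-c3ccccc3O)nn1)C(=O)C2` gives 410 nM, compound 2 `Cc1ccc(-n2cc(CN3C(=O)C[C@@H]4CC[C@@]3(C)C4(C)C)nn2)cc1` gives 390 nM, and compound 3 `CC1(C)[C@H]2CC[C@]1(C)N(Cc1cn(-c3ccccc3F)nn1)C(=O)C2` gives 300 nM. On these numbers compound 2 stands second highest of the three, with compound 1 its nearest neighbour and compound 3 its furthest, and every pair lies within the scatter of repeated measurements. Compound 4 `Cc1cccc(-n2cc(CN3C(=O)C[C@@H]4CC[C@@]3(C)C4(C)C)nn2)c1` has not yet been measured. It differs from compound 2 in one place: 3-methylphenyl in place of 4-methylphenyl on an aromatic nitrogen. The three measured steps each swap one group on the same aromatic nitrogen, and all were small: a 1.1-fold lower number from compound 1 to compound 2 (0.02 log units; within the scatter), a 1.4-fold lower number from compound 1 to compound 3 (0.14 log units; within the scatter), and a 1.3-fold lower number from compound 2 to compound 3 (0.11 log units; within the scatter). With all three of those steps within the scatter, the step expected in this assay is likewise none beyond the scatter: no change at the digits printed from compound 2 to compound 4 (within the scatter). Compound 4 is therefore estimated at 390 nM, with a range from 200 nM to 780 nM.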

Compound 4, half-maximal inhibitory concentration: 410 nM
The estimate for compound 4 lay 1.1-fold (0.02 log units) below the measured number; the measured number falls inside the stated range.
By their numbers in this assay, from the lowest: compounds 3, 2, 1 and 4 (each within the scatter of the next).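

Moving the methyl group changes only where it sits on the ring, since the two compounds have the same atoms joined differently, and in this assay this gives a 1.1-fold higher number from compound 2 to compound 4 (0.02 log units; within the scatter). Within the data shown here, the earlier compounds all differed in which group the phenyl ring carried, so this is the first look at position alone, and the 3-methylphenyl group also stays within the scatter of the other two groups, with a 1.4-fold higher number from compound 3 to compound 4 (0.14 log units; within the scatter) and no change at the digits printed from compound 1 to compound 4 (within the scatter). All four compounds therefore remain inseparable on this read-out, and no measurement shown here offers an explanation for that.

From the compounds shown here alone, whether that holds for an amine or a carboxylic acid in place of the methyl, or for a longer chain such as butyl, stays open. A phenyl ring carrying no added group is also not covered by these compounds.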